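Fluoro to bromo: from compound 2 to compound 3

The compounds below may be only part of what the source reports. "The series", "measured", "known", "first", "only" and "open" are said of these compounds alone.

Compound 1 `O=C(/C=C/c1ccc(Br)cc1)Oc1ccc(/C=C2\CCCCC2=O)cc1` gives 127000 nM as its value
Compound 2 `CN(C)CC1CCC/C(=C\c2ccc(OC(=O)/C=C/c3ccc(F)cc3)cc2)C1=O` gives 1840 nM as its value

In a functional assay on L1210 cells (Mus musculus) (a higher number here means a weaker inhibitor, a lower number a stronger inhibitor), compound 2 has the lower of the two numbers, and its gap to compound 1 lies beyond the scatter. These two compounds differ in more than one place, so the gap cannot be tied to any single group. Compound 3 `CN(C)CC1CCC/C(=C\c2ccc(OC(=O)/C=C/c3ccc(Br)cc3)cc2)C1=O` departs from compound 2 in one place bromo in place of fluoro on an aromatic carbon and nowhere else. Among the measured compounds shown here, no measured pair isolates this exchange. With compound 2 at 1840 nM as the only close reference, no step beyond the scatter is expected in this assay in either direction. The expected change is a 1.0-fold higher number from compound 2 to compound 3 (0.01 log units; within the scatter) and so stays small. Compound 3 is estimated at 1900 nM with 800 nM to 4500 nM as the expected range.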

Compound 3, half-maximal inhibitory concentration: 1780 nM
Compound 3: the middle estimate sits 1.1-fold (0.03 log units) above what was measured; measured number inside the range.
By their numbers in this assay, from the lowest: compounds 3 and 2 (each within the scatter of the next); then compound 1.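

The exchange of fluoro for bromo on this aromatic carbon in this assay gives a 1.0-fold lower number from compound 2 to compound 3 (0.01 log units; within the scatter) and so, with only these two groups compared, the place does not tell them apart. Among the compounds shown here, compound 3 also makes the earlier gap readable for the first time: (dimethylamino)methyl in place of hydrogen on a saturated ring carbon gives a 71-fold lower number from compound 1 to compound 3 (1.85 log units; beyond the scatter) and this single exchange now accounts for a large step that could not be tied to any one group before. No measurement at hand gives a reason for either step.

As far as these compounds go, whether a methoxy group or a carboxylic acid on this aromatic carbon would stay as close to fluoro and bromo remains open. From the compounds shown here alone, it is equally open whether the large step needs the dimethylamino group itself or would also hold for a morpholine or a primary amine.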